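Butyl in place of methoxy on compound 2

A few compounds are considered here, and "the series" means these few. Any claim that something is new, unique, unknown or untested is made for them only; others in the source may bear on it.

In a functional assay on HL-60 cells (Homo sapiens) for cytotoxicity, read by WST assay, with a stated time of 48 h (a higher number here means that more compound is needed for the effect, a lower number that less compound is needed), compound 1 (`COc1ccccc1C[C@H]1COC(=O)[C@@H]1Cc1ccc(Cl)c(Cl)c1`) gives 14000 nM and compound 2 (`COc1ccc(C[C@H]2COC(=O)[C@@H]2Cc2ccc(Cl)c(Cl)c2)cc1`) gives 37000 nM as the higher of the two numbers. Among the measured compounds shown here, the only measured step, a 2.6-fold higher number from compound 1 to compound 2 (0.42 log units; beyond the scatter) with 4-methoxyphenyl in place of 2-methoxyphenyl, is modest. Compound 3 (`CCCCc1ccc(C[C@H]2COC(=O)[C@@H]2Cc2ccc(Cl)c(Cl)c2)cc1`) carries butyl in place of methoxy on an aromatic carbon para to a large group. The measured step moves the methoxy and does not replace it, so it offers only a loose guide. With a 2.6-fold higher number from compound 1 to compound 2 (0.42 log units; beyond the scatter) as the sole yardstick of size, a similarly modest step is expected in this assay and its direction is uncertain. A lower number is the likelier direction, since compound 2 stands at the top of the two values. The estimated change is a 2.3-fold lower number from compound 2 to compound 3 (0.36 log units; beyond the scatter) with wide uncertainty. For compound 3 the expected value is 16000 nM with an estimated range from 5000 nM to 50000 nM in this assay.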

Compound 3, half-maximal effective concentration: 9400 nM
The estimate for compound 3 lay 1.7-fold (0.23 log units) above the measured number; measured number inside the range.
By their numbers in this assay, from the lowest: compounds 3 and 1 (each within the scatter of the next); then compound 2.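

In this assay, the aromatic carbon para to a large group proves sensitive not only to where methoxy sits but also to which group occupies it: butyl in place of methoxy gives a 3.9-fold lower number from compound 2 to compound 3 (0.60 log units; beyond the scatter). This change swaps a group with a hydrogen-bond acceptor for an all-carbon chain with none, and the number moves down, whereas the earlier step moved it up. Nothing available explains why this exchange lowers the number.

Among the compounds shown here, the single exchange changes chain size and removes the oxygen together, so it leaves open which of the two goes with the lower number; butoxy at this carbon would keep the oxygen alongside a longer chain. As far as these compounds go, how an amine or a carboxylic acid at this carbon would behave also remains open.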